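The compounds below may be only part of what the source reports. "The series", "measured", "known", "first", "only" and "open" are said of these compounds alone.

Of the compounds shown here, three sharing one core have been measured in a functional assay on the whole organism with Scenedesmus acutus as the target; a higher number here means a weaker inhibitor, a lower number a stronger inhibitor. Compound 1 (`O=C1C2=C(CCCC2)C(=O)N1c1ccc(Cl)cc1F`) gives 24.6 nM, compound 2 (`COC(=O)c1cc(N2C(=O)C3=C(CCCC3)C2=O)c(F)cc1Cl`) gives 110 nM, and compound 3 (`C#CCOc1cc(N2C(=O)C3=C(CCCC3)C2=O)ccc1Cl`) gives 79.4 nM. Compound 3 therefore lies within the scatter of compound 2, while its number is beyond the scatter above that of compound 1.

Compound 4 (`C#CCOc1cc(N2C(=O)C3=C(CCCC3)C2=O)c(F)cc1Cl`) is compound 3 with fluoro in place of hydrogen on an aromatic carbon. Within the data shown here, no measured step isolates this change. Among the measured compounds shown here, the only measured step, a 4.5-fold higher number from compound 1 to compound 2 (0.65 log units; beyond the scatter), is modest and concerns methoxycarbonyl in place of hydrogen, so it bears on the change only indirectly. Compounds 1 and 2 both carry the fluoro group, but they differ from compound 3 in more than that one place, so the support is weak. A modest fall in the number is expected, although a result within the scatter of compound 3 would not be surprising.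

The expected change is a 2.3-fold lower number from compound 3 to compound 4 (0.36 log units; beyond the scatter). The estimated value for compound 4 is 35 nM, with an expected range of 12 nM to 95 nM.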

Compound 4, half-maximal inhibitory concentration: 15.9 nM
The estimate for compound 4 lay 2.2-fold (0.34 log units) above the measured number, within the range that was stated.
By their numbers in this assay, from the lowest: compounds 4 and 1 (each within the scatter of the next); then compounds 3 and 2 (each within the scatter of the next).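

In this assay, among these compounds, fluoro in place of hydrogen on the aromatic carbon ortho to a large group and para to the propargyloxy group gives a 5.0-fold lower number from compound 3 to compound 4 (0.70 log units; beyond the scatter) as the first direct reading of this change. With fluoro held in place, propargyloxy in place of methoxycarbonyl gives a 6.9-fold lower number from compound 2 to compound 4 (0.84 log units; beyond the scatter) on the same core. Propargyloxy in place of hydrogen gives a 1.5-fold lower number from compound 1 to compound 4 (0.19 log units; within the scatter) and stays within the scatter, whereas methoxycarbonyl in place of that hydrogen gives a 4.5-fold higher number from compound 1 to compound 2 (0.65 log units; beyond the scatter) and lies beyond it.

Going by these compounds, whether a methyl group on the fluoro-bearing carbon would match the fluoro step, and whether a longer chain in place of propargyloxy would hold the number, remains open. Nothing available here speaks to the origin of the fluoro step.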